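A few compounds are considered here, and "the series" means these few. Any claim that something is new, unique, unknown or untested is made for them only; others in the source may bear on it.

For the measured compounds named here, compound 1 `Cc1cccc(Cn2cc(COc3ccc4c(=O)ccoc4c3)nn2)c1` is the only member of this small set with a number rather than a limit: in a functional assay on MDA-MB-231 cells (Homo sapiens) for cytotoxicity, read by MTT assay, with a stated time of 48 h (on this read-out lower numbers stand for stronger inhibition and higher numbers for weaker inhibition), compound 1 gives 16000 nM. Compound 2 `Cc1ccccc1Cn1cc(COc2ccc3c(=O)ccoc3c2)nn1` reaches only a limit of the assay in this assay, > 100000 nM. Compound 3 `O=c1ccoc2cc(OCc3cn(Cc4cccc([N+](=O)[O-])c4)nn3)ccc12` likewise stops at a limit in this assay, > 100000 nM. The measured steps are therefore an at least 6.2-fold higher number from compound 1 to compound 2 (0.79 log units; beyond the scatter) and an at least 6.2-fold higher number from compound 1 to compound 3 (0.79 log units; beyond the scatter), both of them at least modest losses that rest on (the limit of > 100000 nM in this assay, at which 2 of the 3 values shown sit).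

Compound 4 `N#Cc1cccc(Cn2cc(COc3ccc4c(=O)ccoc4c3)nn2)c1` is not yet measured. It differs from compound 1 by cyano in place of methyl on an aromatic carbon. Going by the values given here, of the measured steps, the one from compound 1 to compound 3 bears most directly on it, since it also exchanges the methyl on an aromatic carbon for another group, and that exchange cost an at least 6.2-fold higher number from compound 1 to compound 3 (0.79 log units; beyond the scatter). A weakening of comparable size is therefore expected for compound 4 in this assay, with a real chance that only a limit is reported. The estimate for compound 4 is 60000 nM, between 20000 nM and 200000 nM, which as a step is expected to read a 3.8-fold higher number from compound 1 to compound 4 (0.57 log units; beyond the scatter).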

Compound 4, half-maximal inhibitory concentration: > 100000 nM
Compound 4 gave a limit, no number; the forecaster's own chance of this, stated with the estimate: 40%; middle value at least 1.6-fold (0.22 log units) from the limit.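

Going from 3-methylbenzyl to 3-cyanobenzyl gives an at least 6.2-fold higher number from compound 1 to compound 4 (0.79 log units; beyond the scatter) in this assay, so the loss seen with nitro at this place in compound 3 is not confined to nitro. Of the three groups shown at this place, only methyl, in compound 1, gives a number, while cyano and nitro do not. The steps among compound 2, compound 3 and compound 4 cannot be read, so no order among them can be given, since all three stop at the same limit: the limit of > 100000 nM in this assay, at which 3 of the 4 values shown sit.

The compounds shown leave open whether anything other than methyl keeps a measurable value at this place. An ethyl, a methoxy or a chlorine there could settle whether the number in compound 1 is specific to methyl.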